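The compounds below may be only part of what the source reports. "The series", "measured", "known", "first", "only" and "open" are said of these compounds alone.

Measured compounds:
compound 1 `CSc1cccc(CSc2nc(-c3ccc(F)cc3)c(-c3ccncc3)[nH]2)c1` gives 550 nM
compound 2 `CSc1ccc(CSc2nc(-c3ccc(Br)cc3)c(-c3ccncc3)[nH]2)cc1` gives 2400 nM

In a functional assay (Homo sapiens) for inhibition (on this read-out lower numbers stand for stronger inhibition and higher numbers for weaker inhibition), compound 1 holds the lower of the two numbers at 550 nM and compound 2 sits higher at 2400 nM with a gap beyond the usual scatter. Compound 3 `Oc1cccc(CSc2nc(-c3ccc(F)cc3)c(-c3ccncc3)[nH]2)c1` has yet to be measured. Against compound 1 it carries a single change (hydroxy in place of methylsulfanyl on an aromatic carbon) with hydroxy in place of methylsulfanyl on an aromatic carbon, meta to a large group. For the measured compounds named here, no measured pair shows this change, and the two measured compounds differ in more than one place, so they give no guide to its direction. In this assay, as far as these compounds go, the best expectation is therefore no step beyond the scatter, though a larger move either way remains open. The estimated step is a 1.1-fold lower number from compound 1 to compound 3 (0.04 log units; within the scatter) on this expectation. For compound 3 the expected value is 500 nM with an estimated range from 130 nM to 1800 nM as the likely span.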

Compound 3, half-maximal inhibitory concentration: 310 nM
The estimate for compound 3 lay 1.6-fold (0.21 log units) above the measured number, within the range that was stated.
By their numbers in this assay, from the lowest: compounds 3 and 1 (each within the scatter of the next); then compound 2.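

In this assay, replacing 3-(methylsulfanyl)benzyl with 3-hydroxybenzyl gives a 1.8-fold lower number from compound 1 to compound 3 (0.25 log units; within the scatter). At this place on the aromatic ring, meta to a large group, a methylsulfanyl group with no hydrogen-bond donor can therefore give way to a smaller hydroxy group carrying one, without a step beyond the scatter. Nothing measured here accounts for how closely the two compounds read. 

As far as these compounds go, whether a methoxy group, an amine or a carboxylic acid on this same aromatic carbon would also stay within the scatter of compound 1 remains open, as does the effect of a longer chain there. Compound 2 differs from the others in more than one place, so it does not show whether the hydroxy change would read the same on a different background.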